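Replacing trifluoromethyl with vinyl in compound 3

The compounds below may be only part of what the source reports. "The series", "measured", "known", "first", "only" and "open" are said of these compounds alone.

Values in a functional assay on HeLa cells (Homo sapiens) for inhibition, read by CCK-8 assay, with a stated time of 48 h; a lower number here means a stronger inhibitor, a higher number a weaker inhibitor:
- compound 1 `COc1cc(-c2ccnc3cc(-c4c[nH]c5ccccc45)nn23)cc(OC)c1OC`: 195 nM
- compound 2 `COc1cc(-c2ccnc3cc(-c4ccc5cc[nH]c5c4)nn23)cc(OC)c1OC`: 125 nM
- compound 3 `COc1cc(-c2ccnc3cc(-c4ccc(C(F)(F)F)cc4)nn23)cc(OC)c1OC`: 1840 nM

Compound 3 is the weakest inhibitor of the three at 1840 nM. Compound 4 `C=Cc1ccc(-c2cc3nccc(-c4cc(OC)c(OC)c(OC)c4)n3n2)cc1` carries vinyl in place of trifluoromethyl on an aromatic carbon, para to a large group: vinyl in place of trifluoromethyl on an aromatic carbon. The measured steps at this place exchange the whole aromatic substituent: a 9.4-fold higher number from compound 1 to compound 3 (0.97 log units; beyond the scatter) and a 15-fold higher number from compound 2 to compound 3 (1.17 log units; beyond the scatter), whereas a 1.6-fold lower number from compound 1 to compound 2 (0.19 log units; within the scatter). None of them measures this exchange directly. In this assay, no step beyond the scatter is expected, with a slight lean towards a lower number. The estimated step is a 1.7-fold lower number from compound 3 to compound 4 (0.22 log units; within the scatter). For compound 4 the estimate is 1100 nM, with an expected range of 350 nM to 2800 nM.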

Compound 4, half-maximal inhibitory concentration: 882 nM
Compound 4: the middle estimate sits 1.2-fold (0.10 log units) above what was measured; low and high end bracket the measured number.
By their numbers in this assay, from the lowest: compounds 2 and 1 (each within the scatter of the next); then compound 4; then compound 3.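

In this assay, an exchange confined to the substituent on the six-membered aromatic ring gives a 2.1-fold lower number from compound 3 to compound 4 (0.32 log units; beyond the scatter), so this place responds beyond the scatter while the ring itself stays unchanged. The 4-vinylphenyl group still falls short of both indolyl groups, with a 7.1-fold higher number from compound 2 to compound 4 (0.85 log units; beyond the scatter) and a 4.5-fold higher number from compound 1 to compound 4 (0.66 log units; beyond the scatter). No available evidence explains the difference between vinyl and trifluoromethyl.

Still open, on these data alone, is whether ethyl, which keeps both carbons without the double bond, would match vinyl here. An amine or a carboxylic acid at this place also remains to be compared.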